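The source may report more compounds than this note shows. Statements on the series, on what has been measured and on what is new or still open speak of the compounds shown alone.

Three compounds from this series have been examined in a functional assay on cells for antagonist activity at C-C chemokine receptor type 4 (Homo sapiens), read by fluorescence and calcium flux, with stated times of 2.5 s and 45 s; a higher number here means a weaker inhibitor, a lower number a stronger inhibitor. Compound 1 `Cc1nn([C@H](C)c2ccc(Cl)cc2Cl)c2nc(N3CC[C@H](N4CCC[C@H]4CCS(C)(=O)=O)[C@H](C)C3)cnc12` gives 104 nM there. Compound 2 `CC(c1ccc(Cl)cc1Cl)n1ncc2ncc(C3=CCN(C(=O)[C@H]4CCCCN4)CC3)nc21` gives 275 nM in this assay, and compound 3 `C[C@@H]1CC(c2cnc3c(C#N)nn([C@H](C)c4ccc(Cl)cc4Cl)c3n2)=CC[C@@H]1N1CCC[C@H]1C` gives 34 nM. Compound 1 therefore sits second highest of the three numbers: compound 2 lies higher, beyond the scatter, and compound 3 lies lower, also beyond the scatter, so compound 1 is neither the strongest nor the weakest inhibitor of the three.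

Compound 4 `Cc1nn([C@H](C)c2ccc(Cl)cc2Cl)c2nc(N3CC[C@H](N4CCCC4)[C@H](C)C3)cnc12` keeps the core of compound 1 and alters only the pyrrolidine substituent: hydrogen in place of 2-(methylsulfonyl)ethyl on a saturated ring carbon. The group that leaves is a chain without a ring, bearing two hydrogen-bond acceptors, and nothing takes its place but a hydrogen.

Within the data shown here, no measured pair in the set isolates this change, so the size of the step can only be estimated. Compound 3, whose pyrrolidine carries only a methyl, gives 34 nM on a different core, which shows that a small group on that ring can go with a low number. The expectation for compound 4 is a modest weakening, with a step from compound 1 of about a 2.4-fold higher number from compound 1 to compound 4 (0.38 log units; beyond the scatter) in this assay, close to the edge of the scatter. Compound 4 is thus estimated at 250 nM in this assay, within a range of 80 nM to 800 nM.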

Compound 4, half-maximal inhibitory concentration: 69 nM
For compound 4 the middle estimate is 3.6-fold (0.56 log units) above the measured one; the whole stated range lies above it.
By their numbers in this assay, from the lowest: compound 3; then compounds 4 and 1 (each within the scatter of the next); then compound 2.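

In this assay, hydrogen in place of 2-(methylsulfonyl)ethyl on a saturated ring carbon of the pyrrolidine gives a 1.5-fold lower number from compound 1 to compound 4 (0.18 log units; within the scatter), so on this core the two compounds cannot be told apart. Among these compounds, this is the first pair that isolates this position, and it shows that the position accepts both the bare ring and a chain without a ring bearing two hydrogen-bond acceptors, with no difference beyond the scatter in this read-out; the sulfone-bearing chain is therefore not required for a number of this size. Nothing available here accounts for why the two compounds read alike, and no measurement of any property of the group bears on this step.

This single pair leaves open how other groups would read at this same carbon, such as a primary amine, a carboxylic acid, or a longer chain ending in the same methylsulfonyl group. Among the compounds shown here, it also leaves open whether hydrogen and 2-(methylsulfonyl)ethyl would still read alike on a core carrying a nitrile, where no such pair is available.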